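Heteroaryl swap on the urea nitrogen of the piperazine series

The source may hold more compounds than are shown below. What is called first, only, known or untested is meant among the compounds shown, and "the series" means these compounds.

Among the compounds with values here, compound 2 `Cc1nc2cc(NC(=O)N3CCN(Cc4cccc(Oc5ccc(Cl)cc5)c4)CC3)ccc2o1` holds the lower of the two numbers so far. In an assay on isolated protein for inhibition of Fatty-acid amide hydrolase 1 (Rattus norvegicus), with a stated time of 60 min (on this read-out lower numbers stand for stronger inhibition and higher numbers for weaker inhibition), compound 2 gives 200 nM, whereas compound 1 `O=C(Nc1cccc2cn[nH]c12)N1CCN(Cc2cccc(Oc3ccc(Cl)cc3)c2)CC1` gives 6000 nM. Within the data shown here, the only measured step, a 30-fold lower number from compound 1 to compound 2 (1.48 log units; beyond the scatter), shows that the aryl group on the urea nitrogen alone can move the read-out far beyond the scatter. Compound 3 `O=C(Nc1cncc2ccccc12)N1CCN(Cc2cccc(Oc3ccc(Cl)cc3)c2)CC1` carries the change (isoquinolin-4-yl in place of 2-methyl-1,3-benzoxazol-5-yl on an amide-type nitrogen). Among the measured compounds shown here, no measured step tests this exchange directly; the step from compound 1 to compound 2 bears on it only as a sign that this position is sensitive. The incoming group keeps the shared core and removes a donor-free bicyclic aryl for another donor-free bicyclic aryl, so a change of modest size in either direction, or none beyond the scatter, is expected in this assay. The estimate for compound 3 is a step of a 1.3-fold lower number from compound 2 to compound 3 (0.12 log units; within the scatter), giving an expected value of 150 nM with a range from 30 nM to 800 nM.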

Compound 3, half-maximal inhibitory concentration: 8.3 nM
Beside the measured number, compound 3's estimate is 18-fold (1.26 log units) above it, and the stated range ends above it.
By their numbers in this assay, from the lowest: compound 3; then compound 2; then compound 1.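

Isoquinolin-4-yl and 2-methyl-1,3-benzoxazol-5-yl, each of 10 heavy atoms and neither with a hydrogen-bond donor, are not interchangeable on this amide-type nitrogen: in this assay the exchange gives a 24-fold lower number from compound 2 to compound 3 (1.38 log units; beyond the scatter). The full span now seen at this position, a 720-fold lower number from compound 1 to compound 3 (2.86 log units; beyond the scatter), is much wider than the earlier 30-fold lower number from compound 1 to compound 2 (1.48 log units; beyond the scatter), so the choice among these bicyclic aryl groups alone sets the read-out across a very broad range. No measured evidence accounts for the gain with isoquinolin-4-yl.

On these data alone, it remains open whether the ring nitrogen of isoquinolin-4-yl is needed, which a naphthalen-1-yl group on the same nitrogen would test, and whether a single ring such as pyridin-3-yl would serve. As far as these compounds go, whether the order of these three groups holds on another core is also open.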